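This account rests on a few compounds, and the source may have more. Where it says the series, first, only, none or still open, it means among the compounds named here.

Measured so far:
compound 1, `Cc1ccc(CS(=O)(=O)/C(=C/c2c[nH]c3ccccc23)C(=O)c2ccc(Cl)cc2)cc1`, gives 25000 nM
compound 2, `Cc1ccc(S(=O)(=O)/C(=C/c2c[nH]c3ccc(Cl)cc23)C(=O)c2ccc(Br)cc2)cc1`, gives 10000 nM

Both numbers come from a functional assay on DU-145 cells (Homo sapiens) for inhibition, read by trypan blue exclusion, with a stated time of 96 h; on this read-out lower numbers stand for stronger inhibition of growth and higher numbers for weaker inhibition of growth. Of the two, compound 1 gives the higher number, so its growth inhibition is the weaker of the pair; compound 2 stands nearest to it, with a number lower by a margin beyond the usual scatter. The two compounds differ in more than one place, so their gap cannot be tied to any single change.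

Compound 3, `COc1ccccc1/C=C(\C(=O)c1ccc(Cl)cc1)S(=O)(=O)Cc1ccc(C)cc1`, has not yet been measured in this assay. Compared with compound 1 it carries 2-methoxyphenyl in place of 1H-indol-3-yl on a double-bonded chain carbon bound to a double-bonded chain carbon. The shared core and the rest of the molecule stay as in compound 1. For the measured compounds named here, no measured pair shows this change on its own, so its effect has to be guessed. Compound 1 already inhibits growth only weakly, and without a precedent the expected change is small: a mild shift toward a higher number, close to the scatter, is the estimated step of a 1.6-fold higher number from compound 1 to compound 3 (0.20 log units; within the scatter). In this assay compound 3 is expected to give about 40000 nM, likely between 10000 nM and 160000 nM.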

Compound 3, concentration for 50% growth inhibition: 10000 nM
Estimate against measurement, compound 3: 4.0-fold (0.60 log units) above; the measured number falls inside the stated range.
By their numbers in this assay, from the lowest: compounds 2 and 3 (each within the scatter of the next); then compound 1.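

In this assay, for the compounds shown here, putting 2-methoxyphenyl in place of 1H-indol-3-yl on a double-bonded chain carbon bound to a double-bonded chain carbon gives a 2.5-fold lower number from compound 1 to compound 3 (0.40 log units; beyond the scatter) and is the first change here that can be read on its own. The 1H-indol-3-yl group, with its five-membered ring and its hydrogen-bond donor, can therefore leave this place without any loss of growth inhibition, and 2-methoxyphenyl, with one six-membered aromatic ring and a hydrogen-bond acceptor, does modestly better, though growth inhibition remains weak in absolute terms. Nothing available explains why the step goes in this direction.

This single swap alters the ring count, the donor and the acceptor together, and the compounds shown cannot tell which of these matters. A plain phenyl group would test whether the methoxy group contributes at all, and a 2-hydroxyphenyl or 2-aminophenyl group at the same place would show whether a hydrogen-bond donor can be brought back on a single ring without losing this modest gain.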